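A few compounds are considered here, and "the series" means these few. Any claim that something is new, unique, unknown or untested is made for them only; others in the source may bear on it.

Values in an ADME assay on C2C12 cells (Mus musculus) for cytotoxicity (on this read-out higher numbers stand for lower toxicity in this test and lower numbers for higher toxicity in this test), are as follows.
- Compound 1 `OCCCNc1nc(NCc2ccccc2)c2ccccc2n1` gives > 10000 nM (a limit)
- Compound 2 `Oc1cccc(Nc2nc(NCc3ccccc3)c3ccccc3n2)c1` gives 10000 nM (a number)
- Compound 3 `c1ccc(CNc2nc(Nc3ccccn3)nc3ccccc23)cc1` gives > 10000 nM (a limit)

Compound 3 therefore has no exact value on this scale. It sits at a limit that it shares with compound 1 (the limit of > 10000 nM in this assay, at which 2 of the 3 values shown sit), and only compound 2 has a true number.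

The move to compound 4 `Clc1ccc(Nc2nc(NCc3ccccc3)c3ccccc3n2)cc1` changes one group on a nitrogen on an aromatic ring, putting 4-chlorophenyl in place of pyridin-2-yl (4-chlorophenyl in place of pyridin-2-yl on a nitrogen on an aromatic ring). Among the compounds with values here, three measured steps bear on this, and the limits hide the size of all of them. The closest is the swap between 3-hydroxyphenyl and pyridin-2-yl (a number no lower from compound 2 to compound 3 (the limit leaves the size open)), which runs the opposite way, from a ring of carbon only to pyridin-2-yl. The other two (a number no higher from compound 1 to compound 2 (the limit leaves the size open) and a step that the two limits leave unreadable from compound 1 to compound 3) add no readable size either.

The best guide is compound 2 (10000 nM), whose 3-hydroxyphenyl group is the nearest match to 4-chlorophenyl. A small downward step in this assay is therefore expected, if there is any step at all, and another limit is quite possible. Compound 4 is estimated at (9000 nM), with an expected range from 3000 nM to 20000 nM for its measured value. The expected change is (an at least 1.1-fold lower number from compound 3 to compound 4 (0.04 log units; that floor lies within the scatter)).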

Compound 4, half-maximal cytotoxic concentration: 10000 nM
For compound 4 the middle estimate is 1.1-fold (0.05 log units) below the measured one, and the stated range covers the measured number.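

Within the data shown here, at this nitrogen on an aromatic ring, the swap from 3-hydroxyphenyl to 4-chlorophenyl is the first step in this assay with a true number at both ends, and it reads no change at the digits printed from compound 2 to compound 4 (within the scatter). Exchanging these two rings of carbon only, which carry different groups at different ring positions, therefore leaves the read-out unmoved in this pair, so the hydroxy group of compound 2 is not needed to keep this result. The other two steps are a number no higher from compound 3 to compound 4 (the limit leaves the size open) and a number no higher from compound 1 to compound 4 (the limit leaves the size open) and their size cannot be read. Compound 1 and compound 3 each sit at a limit rather than a number: the limit of > 10000 nM in this assay, at which 2 of the 4 values shown sit.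

From the compounds shown here alone, how far the true values of compound 1 and compound 3 lie past that limit stays open, and with it whether 3-hydroxypropyl or pyridin-2-yl differs at all from the two rings of carbon only. Also open, going by these compounds, is whether a different kind of group at this nitrogen, such as a longer chain ending in an amine or a phenyl ring carrying a carboxylic acid, would move the number in this assay beyond the scatter.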